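Compound 3 to compound 4: an expected cytotoxicity value

The source may report more compounds than this note shows. Statements on the series, on what has been measured and on what is new or still open speak of the compounds shown alone.

Of the compounds shown here, three built on one shared core have been measured in an ADME assay on HEL cells (Homo sapiens) for cytotoxicity; on this read-out lower numbers stand for higher toxicity in this test and higher numbers for lower toxicity in this test. Compound 1 `O=C(COc1cccc2ccccc12)N/N=C/c1cccc([N+](=O)[O-])c1` gives 61.2 ug/mL, compound 2 `O=C(COc1cccc2ccccc12)N/N=C/c1ccccc1[N+](=O)[O-]` gives 100 ug/mL, and compound 3 `O=C(COc1cccc2ccccc12)N/N=C/c1cccc(O)c1` gives 62.7 ug/mL. Compound 3 thus holds the second highest of the three numbers; its nearest neighbour is compound 1 and its furthest is compound 2, and in both cases the gap lies within the scatter. Among the compounds with values here, the only single-point change among the measured pairs is a 1.0-fold higher number from compound 1 to compound 3 (0.01 log units; within the scatter), so hydroxy in place of nitro on an aromatic carbon did not move the number beyond the scatter.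

Within the data shown here, compound 4 `COc1ccc(/C=N/NC(=O)COc2cccc3ccccc23)cc1` differs from compound 3 in one place: 4-methoxyphenyl in place of 3-hydroxyphenyl on a carbon with a double bond to nitrogen No measured step follows this same exchange, so the step from compound 1 to compound 3 is the only guide, and it shows that swapping one substituent on this ring for another left the number within the scatter. On that basis no step beyond the scatter is expected in this assay. The step expected from this change is a 1.0-fold higher number from compound 3 to compound 4 (0.02 log units; within the scatter). For compound 4 the value expected in this assay is 65 ug/mL, with a range from 35 ug/mL to 120 ug/mL.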

Compound 4, half-maximal cytotoxic concentration: 100 ug/mL
Compound 4: middle estimate off by 1.5-fold (0.19 log units), on the low side, and the stated range covers the measured number.
By their numbers in this assay, from the lowest: compounds 1, 3, 2 and 4 (each within the scatter of the next).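

In this assay, the exchange of 3-hydroxyphenyl for 4-methoxyphenyl on a carbon with a double bond to nitrogen gives a 1.6-fold higher number from compound 3 to compound 4 (0.20 log units; within the scatter). Within the data shown here, this extends what the earlier compounds showed, since the only step among them swapped one substituent for another on a ring that stayed a 3-substituted phenyl, whereas here the name of the whole aryl group changes, the hydrogen-bond donor of the 3-hydroxyphenyl group is absent from the 4-methoxyphenyl group, and the step still stays within the scatter, so at this position the number tolerates the loss of that donor together with the gain of a heavy atom. Nothing at hand offers any independent information that would explain this result.

Since the substituent and its ring position change together in this step, the compounds shown do not separate the two, and 3-methoxyphenyl or 4-hydroxyphenyl at this position would be needed to tell them apart. They also leave open whether this tolerance extends to an amine or a carboxylic acid on the ring, or to a longer alkoxy chain in place of the methoxy group.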